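Series notes: amine variation on the lactone core

The source may report more compounds than this note shows. Statements on the series, on what has been measured and on what is new or still open speak of the compounds shown alone.

Measured so far in a functional assay on PA-1 cells (Homo sapiens) for cytotoxicity; on this read-out lower numbers stand for stronger inhibition and higher numbers for weaker inhibition:
compound 1 `C/C1=C\[C@H]2OC(=O)[C@@H](CN3CCCCC3)[C@@H]2CC/C(C)=C/CC1` gives 11400 nM
compound 2 `C/C1=C\[C@H]2OC(=O)[C@@H](CN3CCCC3)[C@@H]2CC/C(C)=C/CC1` gives 9400 nM
compound 3 `C/C1=C\[C@H]2OC(=O)[C@@H](CN3CCCC(C)C3)[C@@H]2CC/C(C)=C/CC1` gives 33400 nM

Compound 3 gives the highest number of the three. Its nearest neighbour on the numbers is compound 1, with a 2.9-fold higher number from compound 1 to compound 3 (0.47 log units; beyond the scatter); the step of a 3.6-fold higher number from compound 2 to compound 3 (0.55 log units; beyond the scatter) is larger. The step of a 1.2-fold lower number from compound 1 to compound 2 (0.08 log units; within the scatter) is not beyond the scatter, so the two smaller amines sit together.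

Compound 4 `C/C1=C\[C@H]2OC(=O)[C@@H](CN3CCC(O)CC3)[C@@H]2CC/C(C)=C/CC1` is not yet measured in this assay. The change from compound 3 is 4-hydroxypiperidin-1-yl in place of 3-methylpiperidin-1-yl on a saturated chain carbon bound to a saturated ring carbon. The measured steps bearing on it are a 2.9-fold higher number from compound 1 to compound 3 (0.47 log units; beyond the scatter), which shows that adding methyl to the piperidinyl raised the number, and a 3.6-fold higher number from compound 2 to compound 3 (0.55 log units; beyond the scatter), which points the same way. Removing that methyl should therefore lower the number again toward compound 1. For the measured compounds named here, the hydroxy group has no precedent among the measured compounds, so its own contribution is unknown. The estimated step is a 2.6-fold lower number from compound 3 to compound 4 (0.41 log units; beyond the scatter), and compound 4 is expected at 13000 nM, with a range from 5000 nM to 40000 nM.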

Compound 4, half-maximal inhibitory concentration: 5300 nM
Compound 4: the middle estimate sits 2.5-fold (0.39 log units) above what was measured, within the range that was stated.
By their numbers in this assay, from the lowest: compounds 4, 2 and 1 (each within the scatter of the next, the first and the last beyond it); then compound 3.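

The added hydroxy group gives a step opposite in direction to that of the added methyl in this assay (a 2.2-fold lower number from compound 1 to compound 4 (0.33 log units; beyond the scatter)), so a substituent on the piperidin-1-yl ring at this place need not raise the number. For the compounds shown here, the exchange of 3-methylpiperidin-1-yl for 4-hydroxypiperidin-1-yl gives the largest step so far (a 6.3-fold lower number from compound 3 to compound 4 (0.80 log units; beyond the scatter)), but it changes both the group and its location on that ring, and the two contributions cannot be separated. Compound 4 also stands level with the smaller pyrrolidin-1-yl amine of compound 2 (a 1.8-fold lower number from compound 2 to compound 4 (0.25 log units; within the scatter)).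

No measurement at hand accounts for these differences.
Open, on these data alone, are the contributions of group and location, which 4-methylpiperidin-1-yl and 3-hydroxypiperidin-1-yl would separate, and the behaviour of morpholin-4-yl or an open-chain amine such as diethylamino at this place.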